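The compounds below may be only part of what the source reports. "The series", "measured", "known", "first", "only" and "open" are said of these compounds alone.

In a functional assay on HCC827 cells (Homo sapiens) for cytotoxicity, read by MTT assay, with a stated time of 72 h (a higher number here means a weaker inhibitor, a lower number a stronger inhibitor), compound 1 `CC(=O)Nc1ccc(Nc2ncc3nc(Nc4ccccc4)n(C4CCCC4)c3n2)cc1` gives 0.47 nM. Compound 2 `Cc1cccc(Nc2nc3cnc(Nc4ccc(N5CCN(C)CC5)cc4)nc3n2C2CCCC2)c1`, which carries a different group on its core, gives < 0.01 nM, and this is a limit of the assay, not a number. Compound 2 therefore stands at the limit of < 0.01 nM in this assay, at which 1 of the 2 values shown sits. Going by the values given here, of the two results, the one for compound 2 lies on the stronger side.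

Compound 3 `CN1CCN(c2ccc(Nc3ncc4nc(Nc5ccc(Br)cc5)n(C5CCCC5)c4n3)cc2)CC1` differs from compound 2 in one place, with 4-bromophenyl in place of 3-methylphenyl on a nitrogen on an aromatic ring. Put another way, (3-methylphenyl)amino becomes (4-bromophenyl)amino. Among the compounds with values here, no measured pair shows this swap alone, so the expectation is a cautious one. The estimated step of an at least 3.0-fold higher number from compound 2 to compound 3 (0.47 log units; beyond the scatter) in this assay is modest and points toward a higher number, meaning a somewhat weaker inhibitor. In this assay, compound 3 is expected at 0.03 nM, with an estimated range of 0.005 nM to 0.3 nM.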

Compound 3, half-maximal inhibitory concentration: 2.2 nM
Beside the measured number, compound 3's estimate is 73-fold (1.87 log units) below it; the whole stated range lies below it.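

Going by these compounds alone, this is the first single change at this position, and it shows that the group on this nitrogen matters a great deal: 4-bromophenyl in place of 3-methylphenyl gives an at least 220-fold higher number from compound 2 to compound 3 (2.34 log units; beyond the scatter) in this assay. The size of the effect stands out, as both groups are a six-membered aromatic ring of carbon only with 7 heavy atoms, so these counts do not separate them. The value for compound 2 is a limit and not a number, so the real step could be larger than the one printed: the limit of < 0.01 nM in this assay, at which 1 of the 3 values shown sits.

As far as these compounds go, what stays open is whether the bromine or its place on the ring accounts for the step, as both differ at once in this swap. A 4-methylphenyl or 3-bromophenyl group on the same nitrogen would pull these two apart.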